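A few compounds are considered here, and "the series" means these few. Any claim that something is new, unique, unknown or untested is made for them only; others in the source may bear on it.

Working notes on the series.

Of the compounds shown here, three have been read in a physicochemical assay for solubility, read by nephelometry, measured as kinetic solubility, at pH 6.5; on this read-out lower numbers stand for lower solubility and higher numbers for higher solubility. Compound 1 `NCc1csc(NC(=O)c2cnn[nH]2)n1` sits at the limit of this assay, reported as > 100 ug/mL, which is a limit and not a number (the limit of > 100 ug/mL in this assay, at which 1 of the 3 values shown sits). Compound 2 `NCc1csc(NC(=O)c2cc3ccccc3n2Cc2ccccc2)n1` gives 1.6 ug/mL in this assay. Compound 3 `CC(C)(C)c1cc(C(=O)Nc2ccccc2)n(Cc2ccccc2)n1` gives 1.6 ug/mL in this assay, level with compound 2 at the digits shown and within the scatter of it; no order between compound 2 and compound 3 can be read from these two values.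

Compound 4 `CNCc1csc(NC(=O)c2cc(C(C)(C)C)nn2Cc2ccccc2)n1` is not yet measured. It differs from compound 3 in one place: 4-((methylamino)methyl)-1,3-thiazol-2-yl in place of phenyl on an amide-type nitrogen. The entering group is the same one that compound 2 carries on its amide nitrogen, where compound 2 gives 1.6 ug/mL.

Among the measured compounds shown here, no measured step between two compounds of this set is available, so the size of the change can only be guessed. A small step upward in this assay is expected, close to the edge of the scatter, a 2.5-fold higher number from compound 3 to compound 4 (0.40 log units; beyond the scatter). Compound 4 is accordingly estimated at 4 ug/mL in this assay, between 1.2 ug/mL and 15 ug/mL, with compound 2 at 1.6 ug/mL as the nearest measured anchor for the entering group.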

Compound 4, solubility: 12.5 ug/mL
Compound 4: the middle estimate sits 3.1-fold (0.49 log units) below what was measured; the measured number falls inside the stated range.
By their numbers in this assay, from the lowest: compounds 2 and 3 (each within the scatter of the next); then compound 4. At a limit, above all of these: compound 1.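

In this assay, among the compounds shown here, the step on the amide-type nitrogen, with 4-((methylamino)methyl)-1,3-thiazol-2-yl in place of phenyl, is the first single-place comparison (a 7.8-fold higher number from compound 3 to compound 4 (0.89 log units; beyond the scatter)). It shows that the read-out responds to a change at this place alone, and that this change moves the number upward by more than the scatter. Nothing at hand accounts for the size or direction of this step.

The compounds shown do not separate the contribution of the five-membered aromatic ring from that of the methylamino end of the entering group, since both arrive together in this single step. Also open, as far as these compounds go, is how this assay would read with a dimethylamino group or a carboxylic acid at the end of that chain.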